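A few compounds are considered here, and "the series" means these few. Any claim that something is new, unique, unknown or untested is made for them only; others in the source may bear on it.

Measured to date in this series:

- compound 1, `CN(C)c1nc(N[C@H]2CC[C@@H](NC(=O)c3cccc(C#N)c3)CC2)nc2ccccc12`, 10 nM
- compound 2, `CN(C)c1nc(N[C@H]2CC[C@@H](NC(=O)c3ccc(F)cc3)CC2)nc2ccccc12`, 9.4 nM
- compound 3, `CN(C)c1nc(N[C@H]2CC[C@@H](NC(=O)c3cccc(Cl)c3)CC2)nc2ccccc12`, 4.5 nM

In an assay on HEK293 cells for inhibition of melanin-concentrating hormone receptor 1 (Homo sapiens), read by radioligand binding (on this read-out higher numbers stand for weaker inhibition and lower numbers for stronger inhibition), compound 1 gives the highest of the three numbers. Its number sits within the scatter of that of compound 2 (a 1.1-fold lower number from compound 1 to compound 2 (0.03 log units; within the scatter)), while the step of a 2.2-fold lower number from compound 1 to compound 3 (0.35 log units; beyond the scatter) is modest but beyond the scatter; the step of a 2.1-fold lower number from compound 2 to compound 3 (0.32 log units; beyond the scatter) is of the same size.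

Compound 4, `Cc1cccc(C(=O)N[C@H]2CC[C@@H](Nc3nc(N(C)C)c4ccccc4n3)CC2)c1`, is not yet measured. It differs from compound 1 in one place: methyl in place of cyano on an aromatic carbon. The step that bears most directly on it is a 2.2-fold lower number from compound 1 to compound 3 (0.35 log units; beyond the scatter), where another small group took the place of the same cyano on the same aromatic carbon and the number came down modestly. The step of a 1.1-fold lower number from compound 1 to compound 2 (0.03 log units; within the scatter) shows that a change on the aryl ring of the amide need not move the number at all. On these two steps, the expectation for compound 4 is a step downward from compound 1 that is at most modest, possibly within the scatter, estimated as a 1.4-fold lower number from compound 1 to compound 4 (0.15 log units; within the scatter).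

Compound 4 is therefore expected to give about 7 nM in this assay, with a range of 3.5 nM to 14 nM.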

Compound 4, half-maximal inhibitory concentration: 4.6 nM
Estimate against measurement, compound 4: 1.5-fold (0.18 log units) above; low and high end bracket the measured number.
By their numbers in this assay, from the lowest: compounds 3 and 4 (each within the scatter of the next); then compounds 2 and 1 (each within the scatter of the next).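

In this assay, methyl on this aromatic carbon gives a modest gain over cyano (a step of a 2.2-fold lower number from compound 1 to compound 4 (0.34 log units; beyond the scatter)), so chloro in compound 3 is no longer the only replacement of the nitrile that lowers the number. Methyl and chloro cannot be told apart here (a 1.0-fold higher number from compound 3 to compound 4 (0.01 log units; within the scatter)), and the 3-methylphenyl amide also departs modestly from the 4-fluorophenyl amide (a 2.0-fold lower number from compound 2 to compound 4 (0.31 log units; beyond the scatter)). Nothing on hand explains why cyano differs from these two groups.

Open, on these data alone, is how methoxy, an amine or a carboxylic acid on this carbon would compare with methyl and chloro. Also open, as far as these compounds go, is whether the gap to compound 2 follows the group or its place on the ring, a question that 3-fluorophenyl or 4-methylphenyl amides would address.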